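Ethyl to cyclopropylmethyl on an aromatic nitrogen

The source may report more compounds than this note shows. Statements on the series, on what has been measured and on what is new or still open speak of the compounds shown alone.

Values in a functional assay on DU-145 cells (Homo sapiens) for inhibition, read by trypan blue exclusion, with a stated time of 72 h (a higher number here means a weaker inhibitor, a lower number a stronger inhibitor), so far:
compound 1 `O=c1[nH]c2nc(Nc3ccc4[nH]ccc4c3)ncc2cc1S(=O)(=O)c1ccc(F)cc1F` gives 15000 nM
compound 2 `CCn1c(=O)c(S(=O)(=O)c2ccc(F)cc2F)cc2cnc(Nc3ccc4[nH]ccc4c3)nc21` gives 750 nM

Compound 2 holds the lower number of the two in this assay, and the gap to compound 1 lies beyond the scatter. The next structure is compound 3 `O=c1c(S(=O)(=O)c2ccc(F)cc2F)cc2cnc(Nc3ccc4[nH]ccc4c3)nc2n1CC1CC1`, which differs from compound 2 as follows: cyclopropyl in place of methyl on a saturated chain carbon bound to an aromatic nitrogen. In words, cyclopropyl replaces methyl on a saturated chain carbon bound to an aromatic nitrogen, so ethyl becomes cyclopropylmethyl.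

Within the data shown here, only one measured step bears on this change: a 20-fold lower number from compound 1 to compound 2 (1.30 log units; beyond the scatter). That large step, beyond the scatter, replaced hydrogen with ethyl on an aromatic nitrogen. It does not compare one chain with another, so the data give no measure of how a longer or ringed chain behaves. Compound 3 keeps a chain on that nitrogen, so no step beyond the scatter is expected in this assay, though this rests on thin evidence. The expected step is a 1.3-fold lower number from compound 2 to compound 3 (0.10 log units; within the scatter). Compound 3 is estimated at 600 nM, with an expected range of 200 nM to 2000 nM.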

Compound 3, half-maximal inhibitory concentration: 1000 nM
For compound 3 the middle estimate is 1.7-fold (0.22 log units) below the measured one, and the stated range covers the measured number.
By their numbers in this assay, from the lowest: compounds 2 and 3 (each within the scatter of the next); then compound 1.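

Changing ethyl to cyclopropylmethyl on the aromatic nitrogen gives a 1.3-fold higher number from compound 2 to compound 3 (0.12 log units; within the scatter) in this assay, so this read-out does not separate the two chains, even though the second carries one three-membered non-aromatic ring of carbon only and two more heavy atoms in the group exchanged. Set against the hydrogen compound, the new chain gives a 15-fold lower number from compound 1 to compound 3 (1.18 log units; beyond the scatter), which shows that the large step at this position is not confined to ethyl: compounds 2 and 3 both stand well apart from compound 1, and none of the three compounds goes against this. Nothing measured here explains why the two chains read alike or why either differs so much from hydrogen.

Going by these compounds, with only two chains on that nitrogen, it remains open how small a group can be and still keep the number, as with a plain methyl, and how far the chain can grow, as with an n-butyl or a benzyl. A chain ending in an amine or a carboxylic acid would show whether this position accepts more than hydrocarbon groups.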